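The source may hold more compounds than are shown below. What is called first, only, known or untested is meant among the compounds shown, and "the series" means these compounds.

Measured in a functional assay on RPMI-8226 cells (Homo sapiens) for antiproliferative activity, read by radiometric assay, with a stated time of 72 h; on this read-out lower numbers stand for stronger inhibition and higher numbers for weaker inhibition:
- compound 1 `Cc1ccccc1Nc1ncnc2cc(NC(=O)CCCCCCC(=O)NO)sc12`: 1750 nM
- compound 2 `CCc1cccc(Nc2ncnc3cc(NC(=O)CCCCCCC(=O)NO)sc23)c1`: 1570 nM

Compound 2, at 1570 nM, cannot be separated from compound 1, at 1750 nM, since the two values lie within the scatter of each other. The next compound to be read is compound 3 `CCc1ccc(Nc2ncnc3cc(NC(=O)CCCCCCC(=O)NO)sc23)cc1`, with 4-ethylphenyl in place of 3-ethylphenyl on a nitrogen on an aromatic ring.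

Among the measured compounds shown here, only one measured step bears on this change, a 1.1-fold lower number from compound 1 to compound 2 (0.05 log units; within the scatter), which also alters the group on that nitrogen and stays within the scatter. For the measured compounds named here, it is thin evidence, and no measured compound carries the 4-ethylphenyl group. No direction can be drawn from it, so no shift beyond the scatter is expected in this assay. The estimated step is a 1.0-fold lower number from compound 2 to compound 3 (0.02 log units; within the scatter). For compound 3 the expected value is 1500 nM, with an estimated range of 700 nM to 3200 nM.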

Compound 3, half-maximal inhibitory concentration: 2540 nM
Compound 3: middle estimate off by 1.7-fold (0.23 log units), on the low side, within the range that was stated.
By their numbers in this assay, from the lowest: compounds 2, 1 and 3 (each within the scatter of the next).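

Among the compounds shown here, the step from this assay gives the first pair with the same atoms joined differently: a 1.6-fold higher number from compound 2 to compound 3 (0.21 log units; within the scatter) leaves 3-ethylphenyl and 4-ethylphenyl on that nitrogen inseparable in this read-out. The second step, a 1.5-fold higher number from compound 1 to compound 3 (0.16 log units; within the scatter) also stays within the scatter, so 2-methylphenyl and 4-ethylphenyl cannot be told apart either, and all three compounds shown read alike at this position. Nothing at hand bears on why the values fall as they do.

Still open, on these data alone, is whether a carboxylic acid or an amine on the phenyl ring, or a longer chain in place of ethyl, would carry the number beyond the scatter. As far as these compounds go, whether a plain phenyl on that nitrogen would read like these three also remains unknown.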